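Propyl to isopropyl on the amide, with only limits so far

This account rests on a few compounds, and the source may have more. Where it says the series, first, only, none or still open, it means among the compounds named here.

In a functional assay on cells (Platelet, Homo sapiens) for inhibition (on this read-out higher numbers stand for weaker inhibition and lower numbers for stronger inhibition), compound 1 (`CCCOC(=O)c1ccc(-c2nn(Cc3ccccc3)c3ccccc23)cc1`) gives > 10000 nM as a limit of the read-out. Compound 2 (`CNC(=O)c1ccc(-c2nn(Cc3ccccc3)c3ccccc23)cc1`) gives > 10000 nM as a limit too. Compound 3 (`CCCNC(=O)c1ccc(-c2nn(Cc3ccccc3)c3ccccc23)cc1`) gives > 10000 nM as a limit as well, so it has no number of its own. For the measured compounds named here, the series so far comes down to the limit of > 10000 nM in this assay, at which 3 of the 3 values shown sit, and nothing more.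

Compound 4 (`CC(C)NC(=O)c1ccc(-c2nn(Cc3ccccc3)c3ccccc23)cc1`) carries isopropyl in place of propyl on an amide-type nitrogen, with isopropyl in place of propyl on an amide-type nitrogen as the counted difference.

The closest measured change is a step that the two limits leave unreadable from compound 2 to compound 3 at that same amide. Less close are a step that the two limits leave unreadable from compound 1 to compound 2 and a step that the two limits leave unreadable from compound 1 to compound 3 and neither of them gives a size. Going by the values given here, no measured step therefore points in either direction, and no step beyond the scatter is expected in this assay for this change. The estimated step is a step that the limit leaves unreadable from compound 3 to compound 4 with no direction favoured. For compound 4 the estimated value is 15000 nM with an expected range from 5000 nM to 50000 nM and a bare limit as the likeliest report.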

Compound 4, half-maximal inhibitory concentration: > 10000 nM
Compound 4: a limit, no number (the forecaster's own chance of this, stated with the estimate: 85%); the middle value is on the limit's open side.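

In this assay compound 4 gives > 10000 nM, a limit and not a number, so its steps from compound 1, compound 2 and compound 3 cannot be read. The series rests on a single reading: the limit of > 10000 nM in this assay, at which 4 of the 4 values shown sit. The compounds shown leave open whether any change on the shared core gives a measurable value in this assay.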